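Adding an amino group to a chloromethylbenzyl purine pair

The source may hold more compounds than are shown below. What is called first, only, known or untested is meant among the compounds shown, and "the series" means these compounds.

Of the compounds shown here, three have been measured in a functional assay on OVCAR-5 cells (Homo sapiens) for cytotoxicity, read by sulforhodamine B assay, with a stated time of 48 h; a lower number here means a stronger inhibitor of growth, a higher number a weaker inhibitor of growth. Compound 1 `ClCc1ccc(Cn2cnc3c(Cl)ncnc32)cc1` gives 9230 nM in this assay. Compound 2 `Nc1nc(Cl)c2ncn(Cc3ccc(CCl)cc3)c2n1` carries one further group, (amino in place of hydrogen on an aromatic carbon), and in this assay compound 2 gives 14800 nM, which amounts to a 1.6-fold higher number from compound 1 to compound 2 (0.21 log units; within the scatter). Compound 3 `ClCc1ccccc1Cn1cnc2c(Cl)ncnc21` has the same atoms as compound 1 joined differently; the difference between the two cores is not broken down here. In this assay compound 3 gives 6600 nM, a number that sits within the scatter of compound 1 and beyond it only against compound 2.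

Compound 4 `Nc1nc(Cl)c2ncn(Cc3ccccc3CCl)c2n1` has not yet been measured. It stands to compound 3 as compound 2 stands to compound 1: the change is amino in place of hydrogen on an aromatic carbon, the same change as that from compound 1 to compound 2, made on the core of compound 3 instead of the core of compound 1. For the measured compounds named here, the one measured instance of this change, a 1.6-fold higher number from compound 1 to compound 2 (0.21 log units; within the scatter), stayed within the scatter. Because of that step from compound 1 to compound 2, and because compound 3 gives 6600 nM, compound 4 is expected to show a similar small move, a 1.5-fold higher number from compound 3 to compound 4 (0.18 log units; within the scatter), in this assay. The estimate for compound 4 in this assay is therefore 10000 nM, with the range 5500 nM to 20000 nM, and the measured value will show whether this holds.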

Compound 4, concentration for total growth inhibition: 39800 nM
The estimate for compound 4 lay 4.0-fold (0.60 log units) below the measured number; measured number above the stated range.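

On the core of compound 3, amino in place of hydrogen on an aromatic carbon gives a 6.0-fold higher number from compound 3 to compound 4 (0.78 log units; beyond the scatter) in this assay, a step that lies beyond the scatter and leaves compound 4 the weaker inhibitor of growth of that pair. So the change did not carry over at the same size from the core of compound 1 to the core of compound 3, and the small step on one core proved a poor guide to the step on the other: the same change on two cores in this assay, a 1.6-fold higher number (0.21 log units; within the scatter) from compound 1 to compound 2 and a 6.0-fold higher number (0.78 log units; beyond the scatter) from compound 3 to compound 4, 3.8-fold (0.58 log units) apart, beyond the scatter of two such steps

For the compounds shown here, this shows that, in this small series, the size of the step depends on the core that carries it, but it rests on only two pairs and does not show why the steps differ, nor how the same change would behave on any further core. The compounds shown leave open whether the gap between the two cores is particular to the amino group or would also appear with a methylamino group, a hydroxyl group or a methyl group in the same place. They also leave open whether the same gap would be seen in cell lines other than this one.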